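The source may report more compounds than this note shows. Statements on the series, on what has been measured and on what is new or still open speak of the compounds shown alone.

Measured in a functional assay on BXPC-3 cells (Homo sapiens) for antiproliferative activity, read by MTT assay, with a stated time of 24 h; a higher number here means a weaker inhibitor, a lower number a stronger inhibitor:
- compound 1 `CCn1c(C(=O)NCC(=O)OC)ccc1C(CC)(CC)c1ccc(OCS(=O)(=O)c2ccccc2)c(C)c1`: 20000 nM
- compound 2 `CCn1c(C(=O)NCCN)ccc1C(CC)(CC)c1ccc(OCS(=O)(=O)c2ccccc2)c(C)c1`: 6430 nM
- compound 3 `CCn1c(C(=O)N[C@H](C)C(=O)O)ccc1C(CC)(CC)c1ccc(OCS(=O)(=O)c2ccccc2)c(C)c1`: 20100 nM

Compound 3, at 20100 nM, lies within the scatter of compound 1, and only compound 2 stands apart from it beyond the scatter. Compound 4 `CCn1c(C(=O)N[C@@H](C(=O)O)C(C)C)ccc1C(CC)(CC)c1ccc(OCS(=O)(=O)c2ccccc2)c(C)c1` differs from compound 3 by isopropyl in place of methyl on a saturated chain carbon bound to an amide-type nitrogen and a carbonyl carbon. This turns (1-carboxyethyl)carbamoyl into (1-carboxy-2-methylpropyl)carbamoyl.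

Going by the values given here, no measured step changes this group alone, so the evidence is indirect. The closest is a 1.0-fold higher number from compound 1 to compound 3 (0.00 log units; within the scatter), a change on the same amide-type nitrogen. The modest 3.1-fold higher number from compound 2 to compound 3 (0.49 log units; beyond the scatter) involves 2-aminoethyl, a group absent from compound 4. Three compounds give little basis for predicting a direction.

On the strength of a 1.0-fold higher number from compound 1 to compound 3 (0.00 log units; within the scatter), no step beyond the scatter is expected in this assay. The expected outcome is a 1.3-fold lower number from compound 3 to compound 4 (0.10 log units; within the scatter). For compound 4 the estimated value is 16000 nM, with an expected range of 6500 nM to 38000 nM.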

Compound 4, half-maximal inhibitory concentration: 13900 nM
The estimate for compound 4 lay 1.2-fold (0.06 log units) above the measured number, within the range that was stated.
By their numbers in this assay, from the lowest: compound 2; then compounds 4, 1 and 3 (each within the scatter of the next).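

In this assay, going by these compounds alone, this is the first direct reading of the saturated chain carbon bound to an amide-type nitrogen and a carbonyl carbon: isopropyl in place of methyl gives a 1.4-fold lower number from compound 3 to compound 4 (0.16 log units; within the scatter), so this position tolerates the change without a step beyond the scatter. Within the data shown here, the 1-carboxy-2-methylpropyl group also stays level with (methoxycarbonyl)methyl, at a 1.4-fold lower number from compound 1 to compound 4 (0.16 log units; within the scatter), while 2-aminoethyl remains apart, at a 2.2-fold higher number from compound 2 to compound 4 (0.33 log units; beyond the scatter), making compound 2 the only compound separated from the others beyond the scatter. Nothing measured here offers an explanation for these results.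

From the compounds shown here alone, whether isobutyl, benzyl or hydroxymethyl on the same carbon would also stay within the scatter remains open. So does whether 1-amino-2-methylpropyl-type chains, carrying an amine together with the isopropyl branch, would match compound 2.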